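The source may hold more compounds than are shown below. What is called first, only, known or untested is meant among the compounds shown, and "the series" means these compounds.

The three measured compounds share one core and differ only in the group carried on a double-bonded ring carbon. Compound 1 `CC(=O)N(C(C)=O)C1=C(C#N)C(c2ccc(Cl)cc2)c2sc(Nc3ccc(S(N)(=O)=O)cc3)nc2O1` gives 74300 nM in a functional assay on MCF7 cells (Homo sapiens) for antiproliferative activity, read by sulforhodamine B assay, with a stated time of 48 h; a higher number here means a weaker inhibitor, a lower number a stronger inhibitor. Compound 2 `N#CC1=C(/N=C/c2ccccc2)Oc2nc(Nc3ccc(S(N)(=O)=O)cc3)sc2C1c1ccc(Cl)cc1` gives 45200 nM in this assay, and compound 3 `Cc1ccc(S(=O)(=O)NC2=C(C#N)C(c3ccc(Cl)cc3)c3sc(Nc4ccc(S(N)(=O)=O)cc4)nc3O2)cc1` gives 71700 nM in this assay. Compound 3 holds the second highest of the three numbers, with compound 1 nearest and compound 2 furthest, both within the scatter of it.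

Compound 4 `N#CC1=C(NC(=O)CCl)Oc2nc(Nc3ccc(S(N)(=O)=O)cc3)sc2C1c1ccc(Cl)cc1` carries (chloromethyl)carbonyl in place of (4-methylphenyl)sulfonyl on an amine nitrogen. Among the compounds with values here, three measured steps bear on this kind of exchange at the same position: a 1.6-fold lower number from compound 1 to compound 2 (0.22 log units; within the scatter), a 1.0-fold lower number from compound 1 to compound 3 (0.02 log units; within the scatter) and a 1.6-fold higher number from compound 2 to compound 3 (0.20 log units; within the scatter). Every one of them stays within the scatter, although the groups exchanged range from a short chain to aromatic rings. No listed step therefore gives a reason to expect that replacing one substituent on this nitrogen with another should move the number beyond the scatter in this assay.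

On that basis compound 4 is expected at 65000 nM, within 25000 nM to 170000 nM, which means an expected step of a 1.1-fold lower number from compound 3 to compound 4 (0.04 log units; within the scatter).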

Compound 4, half-maximal inhibitory concentration: 43800 nM
Beside the measured number, compound 4's estimate is 1.5-fold (0.17 log units) above it; measured number inside the range.
By their numbers in this assay, from the lowest: compounds 4, 2, 3 and 1 (each within the scatter of the next).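

In this assay, replacing the (4-methylphenyl)sulfonyl with (chloromethyl)carbonyl on the amine nitrogen gives a 1.6-fold lower number from compound 3 to compound 4 (0.21 log units; within the scatter), so this position tolerates the loss of the aromatic ring from the substituent without a step beyond the scatter. The other two new comparisons agree, with a 1.0-fold lower number from compound 2 to compound 4 (0.01 log units; within the scatter) and a 1.7-fold lower number from compound 1 to compound 4 (0.23 log units; within the scatter), which means that a chlorine-bearing group without a ring now joins the diacetylamino, sulfonyl and benzylidene-type groups with no separation among the four compounds. The data offer nothing that would explain this flat response at the position.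

As far as these compounds go, whether a bare amine or a carboxylic acid at the double-bonded ring carbon, or a longer alkyl chain on the carbonyl, would move the number beyond the scatter remains open. A plain acetyl group on this nitrogen would also be needed to tell whether the chlorine of the (chloromethyl)carbonyl contributes anything.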